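Methylsulfanyl for methoxy on a second core

This account rests on a few compounds, and the source may have more. Where it says the series, first, only, none or still open, it means among the compounds named here.

Measured compounds:
- Compound 1 `CSc1ccc(CNc2nc(SC)nc3ncccc23)cc1`: in a functional assay on CCRF-CEM cells (Homo sapiens) for cytotoxicity, read by MTT assay, with a stated time of 72 h (a lower number here means a stronger inhibitor of growth, a higher number a weaker inhibitor of growth), compound 1 gives 16800 nM.
- Compound 2 `COc1ccc(CNc2nc(SC)nc3ncccc23)cc1`: in this assay compound 2 reaches only the limit of the assay, > 100000 nM.
- Compound 3 `COc1ccc(CNc2nc(SC)nc3ccccc23)cc1`: in this assay compound 3 likewise reaches only the limit of the assay, > 100000 nM.

Compound 1 and compound 2 share one core and differ only in the group on the benzylic ring, where compound 1 carries methylsulfanyl in place of methoxy on an aromatic carbon. That change gave an at least 5.9-fold lower number from compound 2 to compound 1 (0.77 log units; beyond the scatter); since the starting value is a limit, the true size of the step is not known, only its floor.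

Compound 3 carries the methoxy group of compound 2 on a different core; the difference between the two cores is not broken down here. Compound 4 `CSc1ccc(CNc2nc(SC)nc3ccccc23)cc1` is compound 3 with the same kind of change, (methylsulfanyl in place of methoxy on an aromatic carbon), and its place line reads word for word as that of the first pair.

Among the compounds with values here, because the only measured step of this kind, an at least 5.9-fold lower number from compound 2 to compound 1 (0.77 log units; beyond the scatter), starts from a value at which (the limit of > 100000 nM in this assay, at which 2 of the 3 values shown sit), compound 4 is expected to fall below the limit as well, by a step estimated at an at least 2.5-fold lower number from compound 3 to compound 4 (0.39 log units; beyond the scatter) in this assay. The estimated value for compound 4 is 40000 nM, with a range from 15000 nM to 150000 nM, and a real chance that the assay again reports only a limit.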

Compound 4, concentration for total growth inhibition: > 100000 nM
Compound 4: only a limit was reported (the forecaster's own chance of this, stated with the estimate: 40%); middle value at least 2.5-fold (0.39 log units) from the limit.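

In this assay compound 4 reaches only a limit, > 100000 nM. Compound 3 also reaches only a limit, > 100000 nM, so no step from compound 3 to compound 4 can be read: the limit of > 100000 nM in this assay, at which 3 of the 4 values shown sit.

The compounds shown leave open whether methylsulfanyl in place of methoxy changes the number on the core of compound 3 as it did on the core of compound 2.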